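The source may report more compounds than this note shows. Statements on the series, on what has been measured and on what is new or still open speak of the compounds shown alone.

The series contains four compounds that share a core. Compound 1 `CN(C)c1nccc2c1ncn2[C@H]1C[C@H](O)[C@@H](CO)O1` and compound 2 `OC[C@H]1OC(n2cnc3c(NCc4ccccc4)nccc32)[C@H](O)[C@@H]1O` carry a sugar on the core, whereas compound 3 `CCCCCCNc1[nH]ccc2ncnc1-2` and compound 4 `CCNc1[nH]ccc2ncnc1-2` carry a saturated chain on a nitrogen on an aromatic ring. In a functional assay (Homo sapiens) for inhibition of Nucleic Acid, tested at 100 uM (a lower number here means less inhibition, a higher number more inhibition at the concentration tested (going by the name of the read-out)), compound 1 gives 0%, compound 2 gives 32%, and compound 3 gives 53%. Compound 3 therefore stands highest of the three measured numbers; the nearest is compound 2, and compound 1 lies furthest from it, both gaps beyond the scatter. Compound 4 has not yet been measured in this assay. It differs from compound 3 in one place: hydrogen in place of butyl on a saturated chain carbon, two bonds along the chain from a nitrogen on an aromatic ring. Within the data shown here, no pair of measured compounds differs in just one place, so the size of such a step is unknown; the chain is shortened by four carbons, and compound 1, the smallest compound, gives 0%. The step of a number 25 percentage points lower from compound 3 to compound 4 (beyond the scatter) is expected to be a loss of inhibition, beyond the scatter. Compound 4 is expected to give about 28%, within a range from 5% to 55%.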

Compound 4, a percentage reported as inhibition, at one concentration (the size of the read-out at that concentration, not a potency): 3%
For compound 4 the middle estimate is 25 percentage points above the measured one; the whole stated range lies above it.
By their numbers in this assay, from the lowest: compounds 1 and 4 (each within the scatter of the next); then compound 2; then compound 3.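

In this assay, among these compounds, replacing butyl with hydrogen on a saturated chain carbon, two bonds along the chain from a nitrogen on an aromatic ring, gives the first measured single-place step: a number 50 percentage points lower from compound 3 to compound 4 (beyond the scatter). This shows that the position is far from indifferent, since the core stays the same and only the outer part of the chain goes, yet compound 3 gives 53% and compound 4 only 3%. The compounds shown offer nothing that explains why the step is so large.

Going by these compounds, it remains open whether a propyl or butyl chain at this position would keep part of the inhibition, or whether the change with length is gradual or abrupt. Also open, on these data alone, is whether a longer chain, or a chain ending in an amine or a carboxylic acid, would raise or lower it.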